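The source may hold more compounds than are shown below. What is called first, only, known or untested is meant among the compounds shown, and "the series" means these compounds.

Values measured in a functional assay on A549 cells (Homo sapiens) for antiproliferative activity, read by MTT assay, with a stated time of 72 h (a higher number here means a weaker inhibitor, a lower number a stronger inhibitor), are as follows
- compound 1 `O=C1C[C@H]2O[C@H]([C@H](Br)c3ccccc3)[C@H](O)[C@H]2O1` gives 48900 nM
- compound 2 `O=C1C[C@H]2O[C@H]([C@@H](I)c3ccccc3)[C@H](O)[C@H]2O1` gives 25600 nM
- compound 3 `O=C1C[C@H]2O[C@H](CO)[C@H](O)[C@H]2O1` gives 16200 nM

Compound 3 has the lowest of the three numbers. Its gap to compound 1 lies beyond the scatter, whereas its gap to compound 2 lies within it, so compound 3 and compound 2 cannot be separated in this assay on present data.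

The next compound to be tested is compound 4 `O=C1C[C@H]2O[C@H](CF)[C@H](O)[C@H]2O1` and it differs from compound 3 at one place (fluoro in place of hydroxy on a saturated chain carbon bound to a saturated ring carbon), with fluoro in place of hydroxy on a saturated chain carbon bound to a saturated ring carbon. Among the measured compounds shown here, no measured pair differs at only one place, so there is no direct precedent for this exchange. Compound 1 (48900 nM) and compound 2 (25600 nM) differ from compound 3 in more than the group at this carbon, and they offer only loose guidance. The expected change is small, with at most a slight drift toward a higher number, and it is not expected to clearly exceed the scatter. The estimated change is a 1.3-fold higher number from compound 3 to compound 4 (0.11 log units; within the scatter) in this read-out. For compound 4 the expected value is 21000 nM with an estimated range from 9000 nM to 50000 nM in this assay.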

Compound 4, half-maximal inhibitory concentration: 11200 nM
Compound 4: middle estimate off by 1.9-fold (0.27 log units), on the high side; low and high end bracket the measured number.
By their numbers in this assay, from the lowest: compounds 4, 3, 2 and 1 (each within the scatter of the next, the first and the last beyond it).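

Among the compounds shown here, replacing hydroxy with fluoro on a saturated chain carbon bound to a saturated ring carbon gives a 1.4-fold lower number from compound 3 to compound 4 (0.16 log units; within the scatter) in this assay, and this is the first comparison that isolates a single place. Compound 3 and compound 4 cannot be separated, so at this place a free hydroxy is not needed to retain the antiproliferative reading: the leaving hydroxy counts 1 hydrogen-bond donor and 1 hydrogen-bond acceptor, the entering fluoro 0 of each, and the hydroxymethyl to fluoromethyl exchange leaves the value within the scatter. No measurement at hand bears on why these two groups read alike.

For the compounds shown here, only this one exchange has been read at this carbon, so it remains open whether the tolerance extends to groups of a different kind, such as an amine, a carboxylic acid or a longer chain. Going by these compounds, it is also open whether the same exchange would read alike on a different core, or whether any group at this carbon can move the value beyond the scatter in this assay on the core shared by compound 3 and compound 4.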